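The source may report more compounds than this note shows. Statements on the series, on what has been measured and on what is new or still open speak of the compounds shown alone.

In an assay on microsomes from intestinal mucosa for inhibition of acyl-CoA:cholesterol acyltransferase (Oryctolagus cuniculus) (on this read-out higher numbers stand for weaker inhibition and lower numbers for stronger inhibition), compound 1 `CCCCCCCCCCCCCCCCCCOC(=O)Nc1c(OC)cc(OC)cc1OC` gives 7100 nM, while compound 2 `CCCCCCCC/C=C\CCCCCCCCOC(=O)Nc1c(OC)cc(OC)cc1OC` gives 860 nM. The change between them is decyl in place of dec-1-en-1-yl on a saturated chain carbon, eight bonds along the chain from an oxygen next to a carbonyl group, and it made the step of an 8.3-fold higher number from compound 2 to compound 1 (0.92 log units; beyond the scatter). Compound 3 `CCCCCCCC/C=C\CCCCCCCCNC(=O)Nc1c(C(C)C)cccc1C(C)C` gives 28 nM, the lowest of the three numbers; the difference between its core and the core of compound 2 is not broken down here. Compound 4 `CCCCCCCCCCCCCCCCCCNC(=O)Nc1c(C(C)C)cccc1C(C)C` has not yet been measured. It differs from compound 3 by decyl in place of dec-1-en-1-yl on a saturated chain carbon, eight bonds along the chain from an amide-type nitrogen, the same kind of change as the earlier one, though here the place is eight bonds along the chain from an amide-type nitrogen rather than from an oxygen next to a carbonyl group. Because an 8.3-fold higher number from compound 2 to compound 1 (0.92 log units; beyond the scatter) ran toward weaker inhibition, compound 4 is expected to show an 8.2-fold higher number from compound 3 to compound 4 (0.91 log units; beyond the scatter). Compound 4 is therefore estimated at 230 nM, between 70 nM and 800 nM.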

Compound 4, half-maximal inhibitory concentration: 48 nM
Estimate against measurement, compound 4: 4.8-fold (0.68 log units) above, and the stated range ends above it.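

In this assay, decyl in place of dec-1-en-1-yl gave a 1.7-fold higher number from compound 3 to compound 4 (0.23 log units; within the scatter), so on the core of compound 3 the saturated and unsaturated chains cannot be told apart. The change did not carry over in size from one core to the other: the same change on two cores in this assay, an 8.3-fold higher number (0.92 log units; beyond the scatter) from compound 2 to compound 1 and a 1.7-fold higher number (0.23 log units; within the scatter) from compound 3 to compound 4, 4.8-fold (0.68 log units) apart, beyond the scatter of two such steps. These two pairs show that the size of this step is not constant across the series, but they do not show which difference between the cores accounts for the gap, as those cores differ in more than one place.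

The compounds shown leave open how a core combining parts of both cores would respond to the same change. They also leave open whether a shorter chain such as dodecyl, or a chain ending in a carboxylic acid, would respond as either of these pairs did.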